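A few compounds are considered here, and "the series" means these few. Any claim that something is new, unique, unknown or untested is made for them only; others in the source may bear on it.

Measured in an assay for inhibition of inositol hexakisphosphate kinase 3 (Homo sapiens), read by colorimetric assay, coupled enzyme assay and malachite green, with a stated time of 120 min, in the presence of a further agent that is not named here; a higher number here means a weaker inhibitor, a lower number a stronger inhibitor:
compound 1, `O=C(O)/C=C/c1ccc2noc(-c3ccc(OC(F)(F)F)cc3)c2c1`: 8370 nM
compound 2, `CNC(=O)c1ccc2noc(-c3ccccc3)c2c1`: 6830 nM
compound 3, `O=C(O)c1ccc2noc(-c3ccc(-c4cccnc4)cc3)c2c1`: 610 nM

Compound 3 gives the lowest number of the three in this assay; its gaps to compound 2 and to compound 1 both lie beyond the scatter. Going by the values given here, no two measured compounds differ in one place only, so no single step can be read from the set. Compound 4, `O=C(O)c1ccc2noc(-c3ccc(-c4ccncc4)cc3)c2c1`, is compound 3 with pyridin-4-yl in place of pyridin-3-yl on an aromatic carbon. The change keeps every atom and alters only how the six-membered aromatic ring with one hetero atom is joined; nothing measured here speaks to such a change. From compound 3 a step of a 1.1-fold higher number from compound 3 to compound 4 (0.06 log units; within the scatter) in this assay is expected, that is, none beyond the scatter. Compound 4 is estimated at 700 nM, within 250 nM to 2000 nM.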

Compound 4, half-maximal inhibitory concentration: 670 nM
Compound 4: the middle estimate sits 1.0-fold (0.02 log units) above what was measured, within the range that was stated.
By their numbers in this assay, from the lowest: compounds 3 and 4 (each within the scatter of the next); then compounds 2 and 1 (each within the scatter of the next).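

In this assay, pyridin-4-yl in place of pyridin-3-yl on this aromatic carbon gives a 1.1-fold higher number from compound 3 to compound 4 (0.04 log units; within the scatter). This first single-place comparison in the series shows that the assay does not separate these two ways of joining the ring at this position. No supporting measurement bears on this result.

As far as these compounds go, whether a phenyl or morpholine group at this place would match the two pyridinyl groups remains open. Also open, from the compounds shown here alone, is whether a tetrazole could stand in for the carboxylic acid of compound 3 and compound 4.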